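A few compounds are considered here, and "the series" means these few. Any claim that something is new, unique, unknown or untested is made for them only; others in the source may bear on it.

Measured in an ADME assay on Caco-2 cells (Homo sapiens) for permeability, read by LC-MS, in the apical to basolateral direction, with a stated time of 60 min, at pH 6.5; on this read-out higher numbers stand for higher permeability and lower numbers for lower permeability:
compound 1 `COC(C)(C)[C@@H](O)C(=O)N1N=CC[C@H]1C(=O)NCc1cc(Cl)ccc1-n1cnnn1`: 1.7 10^-6 cm/s
compound 2 `O=C([C@H](O)c1ccccc1)N1CC[C@@H]2C[C@@]21C(=O)NCc1cc(Cl)ccc1-n1cnnn1`: 2.6 10^-6 cm/s
compound 3 `CCCC[C@@H](O)C(=O)N1C[C@H]2C[C@H]2[C@H]1C(=O)NCc1cc(Cl)ccc1-n1cnnn1`: 33 10^-6 cm/s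

Compound 1 gives the lowest of the three numbers; compound 2 is nearest and lies within the scatter of it, while compound 3 stands far above, beyond the scatter. For the measured compounds named here, no step between measured compounds that differ in one place is available. Compound 4 `O=C(NCc1cc(Cl)ccc1-n1cnnn1)[C@@H]1CC=NN1C(=O)[C@H](O)c1ccccc1` differs from compound 1 by phenyl in place of 1-methoxy-1-methylethyl on a saturated chain carbon bound to a carbonyl carbon and an oxygen on a saturated carbon. Compound 2 also carries a hydroxy(phenyl)methyl group, on a different core, and its number sits close to that of compound 1. A modest rise in this assay is expected for compound 4, possibly still within the scatter, because compound 2 gives only 2.6 10^-6 cm/s. The expected step is a 2.1-fold higher number from compound 1 to compound 4 (0.31 log units; beyond the scatter). Compound 4 is estimated at 3.5 10^-6 cm/s, in the range 1.5 10^-6 cm/s to 8 10^-6 cm/s.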

Compound 4, apparent permeability: 7 10^-6 cm/s
Compound 4: the middle estimate sits 2.0-fold (0.30 log units) below what was measured; measured number inside the range.
By their numbers in this assay, from the lowest: compounds 1 and 2 (each within the scatter of the next); then compound 4; then compound 3.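

In this assay, for the compounds shown here, phenyl in place of 1-methoxy-1-methylethyl on a saturated chain carbon bound to a carbonyl carbon and an oxygen on a saturated carbon gives a 4.1-fold higher number from compound 1 to compound 4 (0.61 log units; beyond the scatter), the only step that can be read on a single change with the core held constant. The read-out at this position therefore responds to this exchange by more than the usual scatter. Nothing measured here gives a reason for the step.

As far as these compounds go, it remains open whether the same exchange gives a similar step on another core, and what an amine or a carboxylic acid at this position would give.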